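The source may hold more compounds than are shown below. What is called first, only, known or untested is meant among the compounds shown, and "the series" means these compounds.

Among the measured compounds shown here, compound 3 `C=C1C[C@]23C[C@@]1(O)CC[C@H]2c1cc(Br)c(O)c(C)c1[C@@H]3Cn1cc(-c2ccc(F)cc2)nn1` is the only member of this small set with a number in a functional assay on MCF7 cells (Homo sapiens) for cytotoxicity, read by MTT assay, with a stated time of 4 days (on this read-out higher numbers stand for weaker inhibition and lower numbers for stronger inhibition), where compound 3 gives 19200 nM. Compound 2 `C=C1C[C@]23C[C@@]1(O)CC[C@H]2c1cc(Br)c(O)c(C)c1[C@@H]3Cn1cc(-c2ccccc2)nn1` sits at a limit of the assay, > 20000 nM. Compound 1 `C=C1C[C@]23C[C@@]1(O)CC[C@H]2c1ccc(O)c(C)c1[C@@H]3Cn1cc(-c2ccccn2)nn1` likewise sits at a limit, > 20000 nM. For the measured compounds named here, the one measured step, an at least 1.0-fold lower number from compound 2 to compound 3 (0.01 log units; that floor lies within the scatter), is too small to read as a change. Compound 4 `C=C1C[C@]23C[C@@]1(O)CC[C@H]2c1cc(Br)c(O)c(C)c1[C@@H]3Cn1cc(-c2ccccn2)nn1` differs from compound 3 by pyridin-2-yl in place of 4-fluorophenyl on an aromatic carbon. Going by the values given here, compound 1 carries the same pyridin-2-yl group and sits at the limit of > 20000 nM in this assay, at which 2 of the 3 values shown sit, so no step on file shows this group moving a number away from the limit. Compound 4 is therefore expected near the limit, with an estimated step of a 1.3-fold higher number from compound 3 to compound 4 (0.11 log units; within the scatter). Compound 4 is estimated at 25000 nM, within 15000 nM to 60000 nM.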

Compound 4, half-maximal inhibitory concentration: > 20000 nM
Compound 4 gave a limit, no number; the forecaster's own chance of this, stated with the estimate: 70%; the middle value does not contradict the limit.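

In this assay, the result shows an at least 1.0-fold higher number from compound 3 to compound 4 (0.01 log units; that floor lies within the scatter), so replacing 4-fluorophenyl with pyridin-2-yl at this position cannot be read as a change. The steps from compound 1 and from compound 2 to compound 4 cannot be read, with limits at both ends. Pyridin-2-yl now stands at the limit both with bromo in compound 4 and without it in compound 1, and most of the set sits there: the limit of > 20000 nM in this assay, at which 3 of the 4 values shown sit.

From the compounds shown here alone, whether an amine, a carboxylic acid or a longer chain at this position would give a number clear of that limit stays open.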